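Pyridin-4-yl for pyridin-3-yl on the shared core

The compounds below may be only part of what the source reports. "The series", "measured", "known", "first", "only" and "open" are said of these compounds alone.

Compound 1 `COc1ccc(-c2cccnc2)c2cc(C(=O)Nc3ccncc3)oc12` gives 38% in a functional assay on the whole organism for inhibition, with Mus musculus as the target, at a dose of 10 mg/kg by the oral route; on this read-out higher numbers stand for more inhibition at the one dose given (going by the name of the read-out) and lower numbers for less inhibition. Compound 3 `COc1ccc(-c2ccncc2)c2cc(C(=O)Nc3ccncc3)oc12` differs from compound 1 by pyridin-4-yl in place of pyridin-3-yl on an aromatic carbon; in this assay compound 3 gives 48%, and the step of a number 10 percentage points higher from compound 1 to compound 3 (within the scatter) lies within the scatter, so no order between these two is claimed. Compound 2 `COc1ccc(-c2cccnc2)c2cc(C(=O)Nc3ccc(Cn4ccnc4)cc3)oc12` gives 60%, the highest of the three, beyond the scatter from both compound 3 and compound 1; the difference between the cores of compound 1 and compound 2 is not broken down here. Compound 4 `COc1ccc(-c2ccncc2)c2cc(C(=O)Nc3ccc(Cn4ccnc4)cc3)oc12` differs from compound 2 by pyridin-4-yl in place of pyridin-3-yl on an aromatic carbon, the same change as from compound 1 to compound 3, at a place described in the same words. A step of a number 6 percentage points higher from compound 2 to compound 4 (within the scatter) is expected, because the earlier step of a number 10 percentage points higher from compound 1 to compound 3 (within the scatter) stayed within the scatter. In this assay compound 4 is estimated at 66%, expected to fall between 52% and 80%.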

Compound 4, a percentage reported as inhibition, in the whole organism at one dose (the size of the read-out at that dose, not a potency): 60%
The estimate for compound 4 lay 6 percentage points above the measured number; the range from low to high includes it.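

In this assay, pyridin-4-yl in place of pyridin-3-yl on an aromatic carbon gives no change at the digits printed from compound 2 to compound 4 (within the scatter). Set beside the earlier step, the change carries over between the two cores with no difference that can be read: the same change on two cores in this assay, a number 10 percentage points higher (within the scatter) from compound 1 to compound 3 and no change at the digits printed (within the scatter) from compound 2 to compound 4, 10 percentage points apart, within the scatter of two such steps

Neither core gives a step beyond the scatter for this change, but two cores support no rule, and nothing here shows how the change would behave on a third core. Open, from the compounds shown here alone, is what the place para to a methoxy group accepts beyond these two pyridines, for instance a carboxylic acid or a dimethylamino group. A read-out at one dose also gives no potency for any of these compounds.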